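From 2,3-Dichlorophenyl to 4-Cyanophenyl on the Ethenyl Chain

This account rests on a few compounds, and the source may have more. Where it says the series, first, only, none or still open, it means among the compounds named here.

Measured in a functional assay on MCF7 cells (Homo sapiens) for cytotoxicity, read by MTT assay, with a stated time of 72 h; on this read-out lower numbers stand for stronger inhibition and higher numbers for weaker inhibition:

Compound 1 `COc1cc2ncnc(Nc3ccc(F)c(Cl)c3)c2cc1NC(=O)/C=C/c1ccc(F)cc1Cl`: "not active" (no number reported)
Compound 2 `O=C(/C=C/c1cccc(Cl)c1Cl)Nc1cc2c(Nc3ccc(F)c(Cl)c3)ncnc2cc1O[C@H]1CCOC1`: 30100 nM
Compound 3 `COc1ccc(/C=C/C(=O)Nc2cc3c(Nc4ccc(F)c(Cl)c4)ncnc3cc2OC)cc1`: "not active" (no number reported)

Compound 2 stands alone at 30100 nM as the only number shown, while the two other entries carry none, so it cannot be placed on any scale within this set.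

Compound 4 `N#Cc1ccc(/C=C/C(=O)Nc2cc3c(Nc4ccc(F)c(Cl)c4)ncnc3cc2O[C@H]2CCOC2)cc1` has not yet been measured. It keeps all of compound 2 except one group: 4-cyanophenyl in place of 2,3-dichlorophenyl on a double-bonded chain carbon bound to a double-bonded chain carbon. In short, 4-cyanophenyl takes the place of 2,3-dichlorophenyl on a double-bonded chain carbon bound to a double-bonded chain carbon.

Among the compounds with values here, no pair of measured compounds differs in one place only, so the data offer no direct guide to the size of this change. In this assay no step beyond the usual scatter is expected, and neither direction is favoured. This loose expectation rests on compound 2 at 30100 nM and on compound 1 and compound 3, which give no sign of stronger inhibition. A result with no number at all would not be surprising. The expected change is a 1.0-fold lower number from compound 2 to compound 4 (0.00 log units; within the scatter) and remains only an estimate. The estimate for compound 4 is 30000 nM, with an expected range from 10000 nM to 90000 nM as the measurement is awaited.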

Compound 4, half-maximal inhibitory concentration: 9830 nM
For compound 4 the middle estimate is 3.1-fold (0.48 log units) above the measured one; measured number below the stated range.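

In this assay, within the data shown here, the swap of 2,3-dichlorophenyl for 4-cyanophenyl on a double-bonded chain carbon bound to a double-bonded chain carbon gives a 3.1-fold lower number from compound 2 to compound 4 (0.49 log units; beyond the scatter) and provides the first comparison in this set that differs in one place only. The earlier compounds shown here offered no such pair, whereas this step shows that the read-out responds to the group carried on the ethenyl chain when the rest of compound 2 is kept, even though both groups have the same heavy-atom count and one six-membered aromatic ring of carbon only. Nothing measured here bears on the origin of this step.

The compounds shown cannot separate the contribution of the entering nitrile from the loss of the two chlorine atoms, since the single step changes both at once and no phenyl group bearing only one of these features is among them. As far as these compounds go, it also remains open how this assay would read with a dimethylamino group or a carboxylic acid on that phenyl ring, or with a longer chain in place of the ethenyl link.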